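From cyclopropyl to cyclohexyl on the shared core

A few compounds are considered here, and "the series" means these few. Any claim that something is new, unique, unknown or untested is made for them only; others in the source may bear on it.

Compound 1 (`O=C1C(Nc2ccc(I)cc2)=CC(=O)c2c1nc1n2[C@H]2OC[C@@H](O)[C@H]2OC1`) carries 4-iodophenyl on an amine nitrogen, and in a functional assay on MCF7 cells (Homo sapiens) for inhibition, read by sulforhodamine B assay (on this read-out lower numbers stand for stronger inhibition and higher numbers for weaker inhibition), compound 1 gives 3890 nM as a measured number. Compound 2 (`O=C1C(NC2CC2)=CC(=O)c2c1nc1n2[C@H]2OC[C@@H](O)[C@H]2OC1`) reads > 16000 nM in this assay, which is a limit of the assay and not a number. Compound 2 therefore stands at the limit of > 16000 nM in this assay, at which 1 of the 2 values shown sits, and has no exact position.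

Going by the values given here, compound 3 (`O=C1C(NC2CCCCC2)=CC(=O)c2c1nc1n2[C@H]2OC[C@@H](O)[C@H]2OC1`) keeps the shared core and changes only this group: cyclohexyl in place of cyclopropyl on an amine nitrogen. Among the compounds with values here, one measured step bears on this change, an at least 4.1-fold higher number from compound 1 to compound 2 (0.61 log units; beyond the scatter), and its size is only a lower bound. That step shows that the group on this nitrogen can shift the result, but it does not test cyclohexyl itself. A modest move towards stronger inhibition is therefore expected, and compound 3 could still end at the limit. The expected change is an at least 1.6-fold lower number from compound 2 to compound 3 (0.20 log units; that floor lies within the scatter), an estimate made against a limit. For compound 3 the estimated value is 10000 nM, with an expected range from 4000 nM to 22000 nM in this assay.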

Compound 3, half-maximal inhibitory concentration: > 16000 nM
Compound 3: no number, only a limit (the forecaster's own chance of this, stated with the estimate: 40%); middle value at least 1.6-fold (0.20 log units) from the limit.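

Compound 3 now stands with compound 2 at a limit of the assay and not at a number: the limit of > 16000 nM in this assay, at which 2 of the 3 values shown sit. Going from the three-membered to the six-membered non-aromatic carbon ring on this amine nitrogen therefore brings no measurable value in this assay, and the step between compound 2 and compound 3 cannot be read, as both ends are limits. Cyclohexyl in place of 4-iodophenyl gives an at least 4.1-fold higher number from compound 1 to compound 3 (0.61 log units; beyond the scatter), so among the three compounds shown, both carbon rings that are not aromatic sit at the limit and only the 4-iodophenyl compound, compound 1, gives a number.

On these data alone, how far compound 2 and compound 3 lie beyond the limit stays unknown, so any difference between cyclopropyl and cyclohexyl remains hidden. The compounds shown also leave open whether the number of compound 1 depends on the iodine or on the aromatic ring itself, a question that an unsubstituted phenyl or a 4-chlorophenyl on the same nitrogen would bear on.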